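This account rests on a few compounds, and the source may have more. Where it says the series, first, only, none or still open, it means among the compounds named here.

Measured compounds:
Compound 1, `COc1cccc(C(=O)CCc2ccc3c(c2)B(O)OC3)c1`, in an ADME assay on L929 cells (Mus musculus) for cytotoxicity, read by resazurin assay, with a stated time of 72 h (a lower number here means a stronger inhibitor, a higher number a weaker inhibitor), gives > 10 ug/mL, which is a limit of the assay.
Compound 2, `O=C(/C=C/c1ccc2c(c1)B(O)OC2)c1ccccc1`, in this assay gives > 10 ug/mL, which is a limit of the assay.
Compound 3, `COc1cccc(C(=O)/C=C/c2ccc3c(c2)B(O)OC3)c1`, in this assay gives > 10 ug/mL, which is a limit of the assay.

The change from compound 3 to compound 2 is hydrogen in place of methoxy on an aromatic carbon. In this assay it comes out as a step that the two limits leave unreadable from compound 3 to compound 2; both values sit at the limit of > 10 ug/mL in this assay, at which 3 of the 3 values shown sit, so neither the direction nor the size of this step can be read.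

Compound 4, `O=C(CCc1ccc2c(c1)B(O)OC2)c1ccccc1`, is not yet measured in this assay. It differs from compound 1 by hydrogen in place of methoxy on an aromatic carbon. The place lines of the two changes agree word for word, so this is the same change as from compound 3 to compound 2. The difference between the cores of compound 1 and compound 3 is not broken down here.

Because all three measured values sit at the limit of > 10 ug/mL in this assay, at which 3 of the 3 values shown sit, the expected step is a step that the limit leaves unreadable from compound 1 to compound 4 in this assay, most likely again unreadable. Compound 4 is expected to give about 20 ug/mL in this assay, with a range of 8 ug/mL to 60 ug/mL, and most probably only a limit.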

Compound 4, half-maximal inhibitory concentration: > 10 ug/mL
Compound 4: a limit, no number; the forecaster's own chance of this, stated with the estimate: 85%; the middle value is on the limit's open side.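

Compound 1 and compound 4 both give only a limit in this assay, so no new step can be read between them: the limit of > 10 ug/mL in this assay, at which 4 of the 4 values shown sit.

The compounds shown leave open where any of them would give a real number in this assay, and so whether hydrogen in place of methoxy, or the difference between the cores of compound 1 and compound 3, changes the result.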